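From thiophen-2-yl to 4-(trifluoromethyl)phenyl on the shared core

The source may report more compounds than this note shows. Statements on the series, on what has been measured and on what is new or still open speak of the compounds shown alone.

Measured in a functional assay on L1210 cells (Mus musculus) for antiproliferative activity; on this read-out lower numbers stand for stronger inhibition and higher numbers for weaker inhibition
- Compound 1 `COc1cc(C(=O)c2sc(-c3ccc(-c4ccccc4)cc3)cc2N)cc(OC)c1OC` gives > 10000 nM, which is a limit of the assay.
- Compound 2 `COc1ccc(-c2cc(N)c(C(=O)c3cc(OC)c(OC)c(OC)c3)s2)cc1` gives 45 nM.
- Compound 3 `COc1cc(C(=O)c2sc(-c3cccs3)cc2N)cc(OC)c1OC` gives 9.8 nM.

Compound 3 holds the lower of the two actual numbers, and compound 2 is its nearest comparison. Compound 4 `COc1cc(C(=O)c2sc(-c3ccc(C(F)(F)F)cc3)cc2N)cc(OC)c1OC` carries 4-(trifluoromethyl)phenyl in place of thiophen-2-yl on an aromatic carbon. Among the measured compounds shown here, two measured steps bear on this change. Putting thiophen-2-yl in place of 4-methoxyphenyl gave a 4.6-fold lower number from compound 2 to compound 3 (0.66 log units; beyond the scatter). Putting methoxy in place of phenyl gave an at least 220-fold lower number from compound 1 to compound 2 (2.34 log units; beyond the scatter). Compound 4 returns to a substituted phenyl, so a modest to large rise is expected in this assay, which would be a 26-fold higher number from compound 3 to compound 4 (1.41 log units; beyond the scatter) as estimated. The expected value for compound 4 is 250 nM, with an estimated range from 40 nM to 2500 nM.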

Compound 4, half-maximal inhibitory concentration: 370 nM
Compound 4: the middle estimate sits 1.5-fold (0.17 log units) below what was measured, and the stated range covers the measured number.
By their numbers in this assay, from the lowest: compound 3; then compound 2; then compound 4. At a limit, above all of these: compound 1.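

In this assay, 4-(trifluoromethyl)phenyl in place of thiophen-2-yl gives a 38-fold higher number from compound 3 to compound 4 (1.58 log units; beyond the scatter) and leaves thiophen-2-yl with the lowest number shown at this position. Trifluoromethyl in place of methoxy on the phenyl ring gives an 8.2-fold higher number from compound 2 to compound 4 (0.91 log units; beyond the scatter) and so shows that the number moves with the group on that ring, not only with the ring itself. Trifluoromethyl in place of phenyl gives an at least 27-fold lower number from compound 1 to compound 4 (1.43 log units; beyond the scatter) and this step is read against a limit: the limit of > 10000 nM in this assay, at which 1 of the 4 values shown sits.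

The compounds shown leave open how an amine or a carboxylic acid on that phenyl ring would compare, and whether furan-2-yl would match thiophen-2-yl.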